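A few compounds are considered here, and "the series" means these few. Any claim that something is new, unique, unknown or untested is made for them only; others in the source may bear on it.

Measured so far in a physicochemical assay for solubility, with a stated time of 18 h, at pH 7.4; a lower number here means a less soluble compound, a higher number a more soluble compound:
- compound 1 `COc1ccccc1Oc1ccc2c(NCCCNCc3ccco3)ccnc2c1`: 14500 nM
- compound 2 `COc1ccc(Oc2ccc3c(NCCCNCc4cc(F)ccc4OC)ccnc3c2)cc1`: 14500 nM
- compound 3 `COc1cccc(CNCCCNc2ccnc3cc(CCC(C)C)ccc23)c1O`: 4200 nM

Compound 1 and compound 2 stand level at the digits shown, together the highest of the three numbers; compound 3 gives the lowest number, and its gap to compound 1 lies beyond the scatter. Going by the values given here, no pair here differs in a single place, so no measured step can be read off.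

Compound 4 `Cc1cc(C)cc(Cc2ccc3c(NCCCNCc4ccco4)ccnc3c2)c1` is not yet measured. Its change from compound 1 is 3,5-dimethylbenzyl in place of 2-methoxyphenoxy on an aromatic carbon.

With no measured step of this kind in the set, only an expectation can be given: a modest step downward in this assay, probably beyond the scatter but not large. The step from compound 1 to compound 4 is estimated at a 2.9-fold lower number from compound 1 to compound 4 (0.46 log units; beyond the scatter). Compound 4 is expected to give about 5000 nM, within the range 1500 nM to 15000 nM.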

Compound 4, solubility: 4200 nM
Beside the measured number, compound 4's estimate is 1.2-fold (0.08 log units) above it; low and high end bracket the measured number.
By their numbers in this assay, from the lowest: compounds 3 and 4 (each within the scatter of the next); then compounds 1 and 2 (each within the scatter of the next).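

In this assay, going by these compounds alone, the exchange of 2-methoxyphenoxy for 3,5-dimethylbenzyl on this aromatic carbon gives the first readable step: a 3.5-fold lower number from compound 1 to compound 4 (0.54 log units; beyond the scatter). Heavy-atom count and the carbon-only aromatic ring stay the same while the hydrogen-bond acceptors go from 2 to 0, and the read-out at this position does move. No measured evidence bears on the reason for this step.

Which part of the exchange carries the step stays open, as the whole group changes at once. As far as these compounds go, how a morpholine or a carboxylic acid on this carbon would read also remains open.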